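Adding tert-butyl to a compound measured only at a limit

This account rests on a few compounds, and the source may have more. Where it says the series, first, only, none or still open, it means among the compounds named here.

Values in a functional assay on the whole organism with Rattus norvegicus as the target; a higher number here means that more compound is needed for the effect, a lower number that less compound is needed:
- compound 1 `CNS(=O)(=O)CCn1c(=N)sc2cc(OC(F)(F)F)ccc21`: 4 mg/kg
- compound 2 `CN(C)CCn1c(=N)sc2cc(OC(F)(F)F)ccc21`: 2.3 mg/kg
- compound 3 `CN(C)CCn1c(=N)sc2ccccc21`: > 10 mg/kg

Compound 3 stands at > 10 mg/kg, which is a limit of the assay and not a number. Its neighbour, compound 4 `CN(C)CCn1c(=N)sc2cc(C(C)(C)C)ccc21`, has not been measured. It carries tert-butyl in place of hydrogen on an aromatic carbon.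

Among the compounds with values here, one measured step bears directly on this. It changes a group on that same aromatic carbon. Removing trifluoromethoxy gave an at least 4.3-fold higher number from compound 2 to compound 3 (0.63 log units; beyond the scatter). Read in reverse, this suggests that a group at this carbon may lower the number. However, tert-butyl is a different group, so the size of that step carries over only loosely. The side-chain step, a 1.7-fold lower number from compound 1 to compound 2 (0.24 log units; within the scatter), matters little here, since compound 3 and compound 4 share their chain.

In this assay the expected change is an at least 2.5-fold lower number from compound 3 to compound 4 (0.39 log units; beyond the scatter), towards less compound needed. Compound 4 is estimated at about 4 mg/kg, with an expected range of 1.3 mg/kg to 10 mg/kg.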

Compound 4, dose for half-maximal effect: > 10 mg/kg
Compound 4: a limit, no number (the forecaster's own chance of this, stated with the estimate: 15%); middle value at least 2.5-fold (0.39 log units) from the limit.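

In this assay, exchanging trifluoromethoxy for tert-butyl on the same aromatic carbon gives an at least 4.3-fold higher number from compound 2 to compound 4 (0.63 log units; beyond the scatter). This shows that the identity of the group on this carbon matters: the earlier step from compound 2 to compound 3 does not mean that just any group placed here lowers the number. The change from hydrogen to tert-butyl itself cannot be read, since compound 3 and compound 4 both sit at a limit of the assay and not at a number: the limit of > 10 mg/kg in this assay, at which 2 of the 4 values shown sit.

As far as these compounds go, whether methoxy, chlorine or trifluoromethyl on this carbon would act like trifluoromethoxy or like tert-butyl stays open. Also open, from the compounds shown here alone, is whether tert-butyl would give the same result with the methylsulfamoyl chain of compound 1 in place of the dimethylamino chain.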